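Aryl group on the carbonyl carbon: methoxy to difluoro

The source may hold more compounds than are shown below. What is called first, only, known or untested is meant among the compounds shown, and "the series" means these compounds.

Measured so far in a functional assay on OVCAR-5 cells (Homo sapiens) for inhibition, read by sulforhodamine B assay, with a stated time of 48 h; a lower number here means a stronger inhibitor of growth, a higher number a weaker inhibitor of growth:
compound 1 `COc1ccc(-c2cc(/C=C/C(=O)c3ccc(OC)c(OC)c3)[nH]n2)cc1` gives 4090 nM
compound 2 `COc1cc(-c2cc(/C=C/C(=O)c3ccc(Cl)c(Cl)c3)[nH]n2)cc(OC)c1OC` gives > 100000 nM
compound 3 `COc1ccc(C(=O)/C=C/c2cc(-c3cc(OC)c(OC)c(OC)c3)n[nH]2)cc1` gives 3780 nM

Compound 2 gives only a limit in this assay, (the limit of > 100000 nM in this assay, at which 1 of the 3 values shown sits). Compound 3 and compound 1 sit together, their numbers within the scatter of each other; compound 3 has the lowest of the two numbers shown, but that gap is not a difference.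

The next compound is compound 4 `COc1cc(-c2cc(/C=C/C(=O)c3ccc(F)c(F)c3)[nH]n2)cc(OC)c1OC`. It differs from compound 3 in one place: 3,4-difluorophenyl in place of 4-methoxyphenyl on a carbonyl carbon. Among the measured compounds shown here, the only measured step that bears on this place is an at least 26-fold lower number from compound 2 to compound 3 (1.42 log units; beyond the scatter), where a 4-methoxyphenyl on the carbonyl carbon replaced a dihalogenated phenyl and the number fell steeply. Compound 4 goes back toward a dihalogenated phenyl at the same position, so a rise in number, beyond the scatter, is expected. Compound 2 and compound 4 are not linked by a measured step here, and their halogens differ, so the size is uncertain.

Because an at least 26-fold lower number from compound 2 to compound 3 (1.42 log units; beyond the scatter) was large, compound 4 is expected to give 25000 nM. The expected step in this assay is a 6.6-fold higher number from compound 3 to compound 4 (0.82 log units; beyond the scatter), with a range of 6000 nM to 100000 nM; a limit rather than a number is a real possibility.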

Compound 4, concentration for total growth inhibition: 33800 nM
Compound 4: the middle estimate sits 1.4-fold (0.13 log units) below what was measured; the measured number falls inside the stated range.
By their numbers in this assay, from the lowest: compounds 3 and 1 (each within the scatter of the next); then compound 4. At a limit, above all of these: compound 2.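

In this assay, 3,4-difluorophenyl on the carbonyl carbon also gives a weaker inhibitor of growth than 4-methoxyphenyl, with an 8.9-fold higher number from compound 3 to compound 4 (0.95 log units; beyond the scatter), so the loss seen earlier is not confined to 3,4-dichlorophenyl. The two dihalogenated groups also separate from each other, with an at least 2.9-fold lower number from compound 2 to compound 4 (0.47 log units; beyond the scatter), which places 3,4-difluorophenyl between 4-methoxyphenyl and 3,4-dichlorophenyl among these three compounds. Compound 2 remains a limit, so the full size of that last step stays unknown: the limit of > 100000 nM in this assay, at which 1 of the 4 values shown sits.

The compounds shown leave open whether an aminophenyl or a carboxyphenyl on the carbonyl carbon would sit with compound 3 or with compound 4. Also open, from the compounds shown here alone, is whether a phenyl carrying a single fluorine would give the same rise as 3,4-difluorophenyl.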